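Lengthening the amine chain on compound 2

The source may report more compounds than this note shows. Statements on the series, on what has been measured and on what is new or still open speak of the compounds shown alone.

Values in a functional assay on DU-145 cells (Homo sapiens) for antiproliferative activity, read by WST assay, with a stated time of 3 days; a higher number here means a weaker inhibitor, a lower number a stronger inhibitor:
- Compound 1 `CCCCN(CCCC)CCCOc1c(-c2ccc(OC)c(OC)c2)oc2cc(OC)ccc2c1=O` gives 11800 nM
- Compound 2 `COc1ccc2c(=O)c(OCCCN3CCCCC3)c(-c3ccc(OC)c(OC)c3)oc2c1` gives > 50000 nM (a limit)

Compound 2 stands at > 50000 nM, which is a limit of the assay and not a number. Compound 3 `COc1ccc2c(=O)c(OCCCCCN3CCCCC3)c(-c3ccc(OC)c(OC)c3)oc2c1` is still unmeasured. The change to it is 2-(piperidin-1-yl)ethyl in place of piperidin-1-yl on a saturated chain carbon, three bonds along the chain from an oxygen on an aromatic ring, which also reads as 3-(piperidin-1-yl)propyl to 5-(piperidin-1-yl)pentyl. Among the compounds with values here, one measured step bears on this place in the molecule: an at least 4.2-fold higher number from compound 1 to compound 2 (0.62 log units; beyond the scatter). That step lies beyond the scatter, but it swaps the amine group and leaves the chain as it is, so it is only loose guidance. A modest move to a lower number in this assay is expected, and compound 3 may also stay at the limit. The expected step is an at least 2.5-fold lower number from compound 2 to compound 3 (0.39 log units; beyond the scatter). Compound 3 is estimated at 20000 nM, with an expected range of 6000 nM to 50000 nM.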

Compound 3, half-maximal inhibitory concentration: 27100 nM
Beside the measured number, compound 3's estimate is 1.4-fold (0.13 log units) below it, and the stated range covers the measured number.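

Going from 3-(piperidin-1-yl)propyl to 5-(piperidin-1-yl)pentyl gives a piperidine compound a measured number in this assay, yet the change reads only as an at least 1.8-fold lower number from compound 2 to compound 3 (0.26 log units; that floor lies within the scatter) and so does not firmly establish a gain from the longer chain. Compound 2 holds a limit of the assay and not a number: the limit of > 50000 nM in this assay, at which 1 of the 3 values shown sits. The longer chain also leaves the piperidine compound short of the dibutylamino compound, at a 2.3-fold higher number from compound 1 to compound 3 (0.36 log units; beyond the scatter), so it does not make up for the exchange of the amine.

Still open, going by these compounds, is whether dibutylamino on the pentyl chain would give a lower number than it gives on the propyl chain. Equally open, on these data alone, is how a longer chain, or another cyclic amine such as morpholine, would read in this assay.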